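A few compounds are considered here, and "the series" means these few. Any claim that something is new, unique, unknown or untested is made for them only; others in the source may bear on it.

Measured compounds:
compound 1, `CCCCCCCCCCCCCCCCCC1OCC(COCCCCCC[N+](C)(C)C)O1`, > 5 mg/kg
compound 2, `CCCCCCCCCCCCCCC1COC(COCCCCCC[N+](C)(C)C)C1`, > 5 mg/kg

Compound 1 carries a long saturated chain on a five-membered ring with two oxygens, and an ether-linked chain that ends in a charged nitrogen. In a functional assay on artery with platelet-activating factor receptor (Rattus norvegicus) as the target (a lower number here means that less compound is needed, a higher number that more compound is needed for the effect), compound 1 gives > 5 mg/kg, which is a limit of the assay and not a measured number. Compound 2, whose ring holds one oxygen, likewise gives only a limit in this assay, > 5 mg/kg. Both values shown therefore sit at the same limit, as the limit of > 5 mg/kg in this assay, at which 2 of the 2 values shown sit, records, so nothing can be said about an order between compound 1 and compound 2.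

Compound 3, `CCCCCCCCCCCCCCCCCC1OCC(COCCCCCC[n+]2cccc3ccccc32)O1`, is not yet measured. It differs from compound 1 by a group of 10 heavy atoms (9 carbon, 1 nitrogen; one six-membered aromatic ring of carbon only, one six-membered aromatic ring with 1 hetero atom) in place of a group of 4 heavy atoms (3 carbon, 1 nitrogen; no ring), on a saturated chain carbon, six bonds along the chain from an oxygen on a saturated carbon. Among the compounds with values here, no measured step sets a scale for this kind of change. Since both values shown stop at a limit, compound 3 is expected to behave much like compound 1, with a step that stays within the scatter. The step from compound 1 to compound 3 is estimated as a number no higher from compound 1 to compound 3 (the limit leaves the size open). Compound 3 is expected to give about 5 mg/kg in this assay, within 1.5 mg/kg to 20 mg/kg.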

Compound 3, dose for 50% inhibition: 3.8 mg/kg
Estimate against measurement, compound 3: 1.3-fold (0.12 log units) above, and the stated range covers the measured number.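

In this assay compound 3 gives 3.8 mg/kg, the only measured number among the compounds shown. The other two compounds stop at the same limit of the assay, and a limit is not a number: the limit of > 5 mg/kg in this assay, at which 2 of the 3 values shown sit. Going by these compounds, the change sits on a saturated chain carbon, six bonds along the chain from an oxygen on a saturated carbon, where a group with one six-membered aromatic ring of carbon only and one six-membered aromatic ring with 1 hetero atom replaces a group without a ring, keeping the net charge of +1 and giving an at least 1.3-fold lower number from compound 1 to compound 3 (0.11 log units; that floor lies within the scatter), so this position now has a first step, although its true size stays open.

The compounds shown leave open whether a pyridinium group, with a single aromatic ring on the charged nitrogen, or an uncharged amine at the end of the chain would also give a measured number. They also leave open whether the same exchange on the core of compound 2 would do so, and how a longer chain leading to the charged nitrogen would change the result.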